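This account rests on a few compounds, and the source may have more. Where it says the series, first, only, none or still open, it means among the compounds named here.

Measured in a physicochemical assay for solubility, read by HPLC, in phosphate buffer, measured as kinetic solubility, with a stated time of 1 h, at pH 7.4, tested at 250 uM; a lower number here means a less soluble compound, a higher number a more soluble compound:
- compound 1 `CC(C)CNC(=O)n1c(=O)oc2cc(C3CCCCN3C)ccc21`: 190000 nM
- compound 2 `CC(C)CNC(=O)n1c(=O)oc2cc(C3CCCN(C)C3)ccc21`: > 250000 nM, a limit of the assay and not a number

Compound 2 has only a limit to its name: the limit of > 250000 nM in this assay, at which 1 of the 2 values shown sits. The change to compound 3 `CC(C)CNC(=O)n1c(=O)oc2cc(C3CCN(C)CC3)ccc21` is 1-methylpiperidin-4-yl in place of 1-methylpiperidin-3-yl on an aromatic carbon. Among the compounds with values here, the one measured step that bears on it, an at least 1.3-fold higher number from compound 1 to compound 2 (0.11 log units; that floor lies within the scatter), also exchanges one 1-methylpiperidinyl attachment for another, and its floor stays within the scatter. No step beyond the scatter is therefore expected in this assay, in either direction. The expected step is an at least 1.0-fold lower number from compound 2 to compound 3 (0.03 log units; that floor lies within the scatter). For compound 3 the estimate is 230000 nM, with an expected range of 150000 nM to 250000 nM.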

Compound 3, solubility: 240000 nM
Compound 3: the middle estimate sits 1.0-fold (0.02 log units) below what was measured; the range from low to high includes it.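

In this assay, the change to 1-methylpiperidin-4-yl gives the series its first step read between two numbers rather than against a limit: a 1.3-fold higher number from compound 1 to compound 3 (0.10 log units; within the scatter). The other new step, an at least 1.0-fold lower number from compound 2 to compound 3 (0.01 log units; that floor lies within the scatter), gives only a floor. Compound 2 remains a limit of the assay and not a number: the limit of > 250000 nM in this assay, at which 1 of the 3 values shown sits.

All the compounds shown carry a 1-methylpiperidinyl group at this position, so it stays open how this assay responds to a different group there, such as a carboxylic acid or an open-chain amine. As far as these compounds go, the effect of replacing the methyl on the ring nitrogen with a longer chain also remains open.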